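Replacing propanoyl with phenyl in compound 3

The source may hold more compounds than are shown below. What is called first, only, known or untested is meant among the compounds shown, and "the series" means these compounds.

Measured in a functional assay on the whole organism with Mus musculus as the target; on this read-out higher numbers stand for an effect only at larger amounts of compound and lower numbers for an effect already at smaller amounts:
Compound 1 `Cc1c(C)c2c(c(C)c1N)CC(C)(CSc1ccc(F)cc1)O2`: 17.9 mg/kg
Compound 2 `Cc1c(C)c2c(c(C)c1N)CC(C)(CSc1nccn1C)O2`: 37.1 mg/kg
Compound 3 `CCC(=O)Nc1c(C)c(C)c2c(c1C)CC(C)(C)O2`: > 100 mg/kg

Compound 3 sits at the limit of > 100 mg/kg in this assay, at which 1 of the 3 values shown sits, which is a limit and not a number. Compound 4 `Cc1c(C)c2c(c(C)c1Nc1ccccc1)CC(C)(C)O2` has phenyl in place of propanoyl on a nitrogen on an aromatic ring. Within the data shown here, the only measured step, a 2.1-fold higher number from compound 1 to compound 2 (0.32 log units; beyond the scatter), is modest and concerns a group on a sulfur, so it bears on this change only weakly. Among the measured compounds shown here, no measured step changes this nitrogen, so the size of the change in this assay remains uncertain, and compound 4 may also give only a limit. A moderately lower number is expected, and the estimated step is an at least 2.0-fold lower number from compound 3 to compound 4 (0.30 log units; that floor lies within the scatter). For compound 4 the expected value is 50 mg/kg, with an estimated range from 15 mg/kg to 150 mg/kg.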

Compound 4, dose for 50% inhibition: > 50 mg/kg
Compound 4: no number, only a limit; the forecaster's own chance of this, stated with the estimate: 35%; the middle value lies on the limit itself.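

Compound 3 and compound 4 each give only a limit in this assay, not a number, so no step can be read between them. As far as these compounds go, whether phenyl in place of propanoyl on this nitrogen changes the effective dose, and by how much, stays open.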